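Swapping a Fluorophenyl Ether for a Cyclopropyl Ether

The source may report more compounds than this note shows. Statements on the series, on what has been measured and on what is new or still open speak of the compounds shown alone.

Three compounds have been measured in a functional assay on isolated protein for agonist activity at Free fatty acid receptor 1 (Homo sapiens), read by HTRF and inositol phosphate accumulation, with a stated time of 60 min; on this read-out lower numbers stand for an effect already at smaller amounts and higher numbers for an effect only at larger amounts of compound:

Compound 1 `O=C(O)CCCOc1ccc(-c2cc(OC(F)(F)F)ccc2F)cc1` gives 4220 nM.
Compound 2 `O=C(O)CCCOc1ccc(-c2cc(Oc3ccccc3)ccc2F)cc1` gives 3590 nM.
Compound 3 `O=C(O)CCCOc1ccc(-c2cc(Oc3cccc(F)c3)ccc2F)cc1` gives 9460 nM.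

Compound 3 stands highest of the three. The step of a 1.2-fold lower number from compound 1 to compound 2 (0.07 log units; within the scatter) lies within the scatter, while a 2.2-fold higher number from compound 1 to compound 3 (0.35 log units; beyond the scatter) and a 2.6-fold higher number from compound 2 to compound 3 (0.42 log units; beyond the scatter) are both modest but beyond it, so compound 3 is the weakest of the measured set.

Compound 4 `O=C(O)CCCOc1ccc(-c2cc(OC3CC3)ccc2F)cc1` differs from compound 3 by one change: cyclopropyl in place of 3-fluorophenyl on an oxygen on an aromatic ring. For the measured compounds named here, the only measured steps that bear on this are the two that lead into compound 3. The exchange of a small group for the 3-fluorophenyl, a 2.2-fold higher number from compound 1 to compound 3 (0.35 log units; beyond the scatter), cost a modest amount, and the fluoro added to phenyl, a 2.6-fold higher number from compound 2 to compound 3 (0.42 log units; beyond the scatter), cost a similar amount. Replacing the whole 3-fluorophenyl with a small cyclopropyl is expected to undo that loss and return to roughly the level of compound 1, which gives 4220 nM. The expected step is a 2.1-fold lower number from compound 3 to compound 4 (0.32 log units; beyond the scatter). Compound 4 is therefore estimated at 4500 nM, with a range from 1500 nM to 12000 nM.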

Compound 4, half-maximal effective concentration: > 9950 nM
Compound 4 was reported as a limit (the forecaster's own chance of this, stated with the estimate: 5%); at least 2.2-fold (0.34 log units) between middle value and limit.
By their numbers in this assay, from the lowest: compounds 2 and 1 (each within the scatter of the next); then compound 3. At a limit, above all of these: compound 4.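

In this assay, compound 4 is reported only as a limit, not as a number: the limit of > 9950 nM in this assay, at which 1 of the 4 values shown sits. Compound 1 and compound 2 lie within the scatter of each other, so trifluoromethyl and phenyl on this oxygen had looked interchangeable, but cyclopropyl does not join them: the change gives an at least 2.3-fold higher number from compound 1 to compound 4 (0.37 log units; beyond the scatter) and an at least 2.7-fold higher number from compound 2 to compound 4 (0.44 log units; beyond the scatter). Against the 3-fluorophenyl the step reads an at least 1.0-fold higher number from compound 3 to compound 4 (0.02 log units; that floor lies within the scatter), so the order of those two compounds stays unsettled.

On these data alone, the true value of compound 4 remains open. So does the question of whether a methyl or a cyclohexyl on this oxygen would fall with the trifluoromethyl and phenyl compounds or with the cyclopropyl one.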